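A Ring Nitrogen Enters the Amine Substituent of Compound 1

This account rests on a few compounds, and the source may have more. Where it says the series, first, only, none or still open, it means among the compounds named here.

Compound 1 `COc1ncc(-c2ccc3ncnc(Nc4ccc(OCCO)cc4)c3c2)cc1NS(=O)(=O)c1ccc(F)cc1F`: 1060 nM
Compound 2 `COC(=O)Cn1cc(Nc2ncnc3ccc(-c4cnc(OC)c(NS(=O)(=O)c5ccc(F)cc5F)c4)cc23)cn1`: 1260 nM
Compound 3 `COc1cc(Nc2ncnc3ccc(-c4cnc(OC)c(NS(=O)(=O)c5ccc(F)cc5F)c4)cc23)ccc1OCCO`: 5720 nM

Of the compounds shown here, three built on a shared core have been tested in a functional assay on HCT-116 cells (Homo sapiens) for antiproliferative activity, read by sulforhodamine B assay, with a stated time of 72 h; on this read-out higher numbers stand for weaker inhibition and lower numbers for stronger inhibition. Compound 1 shows the lowest number of the three. Compound 2 sits very close to it: a 1.2-fold higher number from compound 1 to compound 2 (0.08 log units; within the scatter). Compound 3 lies further away: a 5.4-fold higher number from compound 1 to compound 3 (0.73 log units; beyond the scatter), and the gap between compound 2 and compound 3 is also beyond the scatter: a 4.5-fold higher number from compound 2 to compound 3 (0.66 log units; beyond the scatter).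

Compound 4 `COc1ncc(-c2ccc3ncnc(Nc4ccc(OCCO)nc4)c3c2)cc1NS(=O)(=O)c1ccc(F)cc1F` is the compound still to be measured. Compared with compound 1 the change is 6-(2-hydroxyethoxy)pyridin-3-yl in place of 4-(2-hydroxyethoxy)phenyl on a nitrogen on an aromatic ring. For the measured compounds named here, no measured pair exchanges a ring carbon for a ring nitrogen in this group, so there is no direct guide. What the measured steps do show is that a quite different group on this nitrogen, as in compound 2, leaves the number within the scatter, whereas an added methoxy on the ring, as in compound 3, costs a modest step upward. Going by the values given here, the change in compound 4 keeps the 2-hydroxyethoxy group and alters only one ring atom, so the expected step is small and within the scatter: a 1.2-fold higher number from compound 1 to compound 4 (0.09 log units; within the scatter). For compound 4 the expected value is 1300 nM, with a range from 500 nM to 3500 nM.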

Compound 4, half-maximal inhibitory concentration: 2340 nM
For compound 4 the middle estimate is 1.8-fold (0.26 log units) below the measured one; the range from low to high includes it.
By their numbers in this assay, from the lowest: compounds 1, 2 and 4 (each within the scatter of the next, the first and the last beyond it); then compound 3.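

In this assay, exchanging a single ring carbon of the 4-(2-hydroxyethoxy)phenyl group for nitrogen, which gives 6-(2-hydroxyethoxy)pyridin-3-yl, produces a modest but real step (a 2.2-fold higher number from compound 1 to compound 4 (0.34 log units; beyond the scatter)), so the ring itself matters at this place even when the 2-hydroxyethoxy chain stays unchanged. For the compounds shown here, the new group also separates from the methoxy-bearing group of compound 3 (a 2.4-fold lower number from compound 3 to compound 4 (0.39 log units; beyond the scatter)), yet it cannot be told apart from the quite different pyrazole group of compound 2 (a 1.9-fold higher number from compound 2 to compound 4 (0.27 log units; within the scatter)), so this small exchange has a measurable cost without moving the number outside the span set by the earlier compounds. Nothing available here explains how the ring nitrogen produces this step.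

The compounds shown leave open whether the ring nitrogen would carry the same cost with another chain on the ring, such as a 2-aminoethoxy group or a longer 3-hydroxypropoxy chain. They also leave open whether the added methoxy of compound 3 would have the same effect on the 6-(2-hydroxyethoxy)pyridin-3-yl group.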